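Ortho-oxygen substituents on the benzyl-pyrimidine series: next step

The source may hold more compounds than are shown below. What is called first, only, known or untested is meant among the compounds shown, and "the series" means these compounds.

Measured compounds:
compound 1 `Nc1ncc(Cc2ccccc2O)c(N)n1`, 89100 nM
compound 2 `COc1ccccc1Cc1cnc(N)nc1N`, 28800 nM
compound 3 `CS(=O)(=O)Oc1ccccc1Cc1cnc(N)nc1N`, 22900 nM

All three share one core and differ only in what sits on the oxygen on the aromatic ring. In an assay for inhibition of Dihydrofolate reductase (Gallus gallus) (on this read-out lower numbers stand for stronger inhibition and higher numbers for weaker inhibition), compound 1 gives 89100 nM; capping the oxygen lowers the number: a 3.1-fold lower number from compound 1 to compound 2 (0.49 log units; beyond the scatter) and a 3.9-fold lower number from compound 1 to compound 3 (0.59 log units; beyond the scatter). Between the two caps the difference is small, a 1.3-fold lower number from compound 2 to compound 3 (0.10 log units; within the scatter). Compound 3 therefore holds the lowest number of the three, but it is within the scatter of compound 2 and clearly separated only from compound 1.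

Compound 4 `Nc1ncc(Cc2ccccc2OCc2ccccc2)c(N)n1` continues the same series with the change (benzyl in place of methylsulfonyl on an oxygen on an aromatic ring). Among the compounds with values here, the steps that bear on it are those from compound 1 to compound 2 and from compound 1 to compound 3, both modest and both in the same direction, plus the step from compound 2 to compound 3, which is within the scatter. Any capped oxygen has so far given a comparable number; the benzyl cap has no direct precedent. Compound 4 is therefore expected to stay close to compound 3, with the step of a 1.3-fold lower number from compound 3 to compound 4 (0.13 log units; within the scatter) expected to fall within the scatter. The estimate for compound 4 in this assay is 17000 nM, range 4500 nM to 65000 nM.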

Compound 4, inhibition constant: 9120 nM
For compound 4 the middle estimate is 1.9-fold (0.27 log units) above the measured one, within the range that was stated.
By their numbers in this assay, from the lowest: compound 4; then compounds 3 and 2 (each within the scatter of the next); then compound 1.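

On the oxygen on the aromatic ring, the nature of the cap now matters in this assay: benzyl gives a 2.5-fold lower number from compound 3 to compound 4 (0.40 log units; beyond the scatter) and a 3.2-fold lower number from compound 2 to compound 4 (0.50 log units; beyond the scatter), both beyond the scatter, whereas methylsulfonyl and methyl could not be told apart. With a 9.8-fold lower number from compound 1 to compound 4 (0.99 log units; beyond the scatter) on top of these, compound 4 is the strongest inhibitor of the four, and its cap is made of carbon only, one six-membered aromatic ring with no hydrogen-bond acceptors counted on it, so the methylsulfonyl acceptors are not needed to reach the lowest number in the series. No measurement to hand explains why benzyl gives this lower number.

Still open, going by these compounds, is whether the aromatic ring of the cap accounts for the step, which a cyclohexylmethyl group on the same oxygen would test, and whether a longer chain such as phenylethyl keeps the lower number. Also open, on these data alone, is how far the number moves when the benzyl ring itself carries a further group, such as an amine or a carboxylic acid.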